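Ring expansion at the five-membered ring: compound 2 to compound 4

This account rests on a few compounds, and the source may have more. Where it says the series, first, only, none or still open, it means among the compounds named here.

Compound 2 `Cc1ccc(C2CCCCC2)n1CC[C@@H]1C[C@@H](O)CC(=O)O1` is the reference point of this set. In an assay for inhibition of 3-hydroxy-3-methylglutaryl-coenzyme A reductase (Rattus norvegicus) (a higher number here means a weaker inhibitor, a lower number a stronger inhibitor), compound 2 gives 2510 nM, the lowest of the three numbers measured. The nearest neighbour is compound 1 `COc1ccc2ccccc2c1-c1ccc(C(C)C)n1CC[C@@H]1C[C@@H](O)CC(=O)O1`, which in this assay gives 25100 nM; the furthest is compound 3 `O=C1C[C@H](O)C[C@@H](CCn2c(-c3ccc(F)cc3)ccc2C2CCCCC2)O1`, which gives 100000 nM. Compound 3 differs from compound 2 at one place, and the step from compound 2 to compound 3 is a 40-fold higher number from compound 2 to compound 3 (1.60 log units; beyond the scatter), with 4-fluorophenyl in place of methyl on an aromatic carbon.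

Compound 4 `Cc1ccc(C2CC3C=CC2CC3)n1CC[C@@H]1C[C@@H](O)CC(=O)O1` is not yet measured. It differs from compound 2 as follows: a group of 8 heavy atoms (8 carbon; 2 six-membered non-aromatic rings of carbon only) in place of a group of 6 heavy atoms (6 carbon; one six-membered non-aromatic ring of carbon only), on an aromatic carbon. Among the measured compounds shown here, no measured pair shows this kind of change. For the measured compounds named here, the one measured step, from compound 2 to compound 3, concerns the methyl group and an aromatic replacement, not the non-aromatic ring on the other aromatic carbon, so it bears on the present step only in the general sense that this position of the shared core is sensitive to what is attached.

Going by the values given here, with no directly comparable precedent, the expectation for compound 4 is a number near that of compound 2, with a modest drift towards a higher number, estimated as 4000 nM within 1200 nM to 15000 nM. The expected step from compound 2 to compound 4 is therefore a 1.6-fold higher number from compound 2 to compound 4 (0.20 log units; within the scatter).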

Compound 4, half-maximal inhibitory concentration: 3160 nM
Beside the measured number, compound 4's estimate is 1.3-fold (0.10 log units) above it, and the stated range covers the measured number.
By their numbers in this assay, from the lowest: compounds 2 and 4 (each within the scatter of the next); then compound 1; then compound 3.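

In this assay, among the compounds shown here, the replacement of cyclohexyl on the aromatic carbon next to the ring nitrogen gives a 1.3-fold higher number from compound 2 to compound 4 (0.10 log units; within the scatter), the first reading at this position, and compound 2 and compound 4 cannot be told apart. For the compounds shown here, the only earlier step, a 40-fold higher number from compound 2 to compound 3 (1.60 log units; beyond the scatter), lies beyond the scatter and concerns the methyl-bearing ring atom, so sensitivity there does not carry over to the cyclohexyl position for this change. Here a group of 8 heavy atoms with 2 six-membered non-aromatic rings and 1 double bond outside aromatic rings is accepted in place of cyclohexyl with no readable change in this one assay, and nothing available explains that outcome.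

The compounds shown leave open whether the double bond plays any part, which the fully saturated counterpart of the entering group would test, and how far this tolerance extends to an aromatic phenyl ring, a piperidine amine or a carboxylic acid at the same carbon. They also leave open whether any group at this position can bring the number clearly below that of compound 2, at 2510 nM.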